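The compounds below may be only part of what the source reports. "The series", "measured", "known", "first", "only" and "open" are said of these compounds alone.

Measured compounds:
- compound 1 `COc1ccc(-c2cc(/C=C/C(=O)c3ccc(N)cc3)[nH]n2)cc1`; in a functional assay on MCF7 cells (Homo sapiens) for cytotoxicity, read by sulforhodamine B assay, with a stated time of 48 h, tested at 0.01 uM (a lower number here means a stronger effect, a higher number a weaker effect of the compound at the concentration tested), compound 1 gives 84%
- compound 2 `COc1cc(-c2cc(/C=C/C(=O)c3ccc(Cl)c(Cl)c3)[nH]n2)cc(OC)c1OC`; in this assay compound 2 gives 105%

Compound 2 has the highest of the two numbers in this assay; the nearest is compound 1, whose number is lower by an amount beyond the usual scatter. The account now turns to compound 3 `COc1ccc(C(=O)/C=C/c2cc(-c3cc(OC)c(OC)c(OC)c3)n[nH]2)cc1`, which has not yet been measured. Compared with compound 2, the change is 4-methoxyphenyl in place of 3,4-dichlorophenyl on a carbonyl carbon. Within the data shown here, no step between measured compounds that differ in one place is available, so this change is taken as carrying no clear expected direction. Compound 3 is therefore estimated in this assay at 97%, with a range from 78% to 115%. This estimate means a step of a number 8 percentage points lower from compound 2 to compound 3 (within the scatter), expected to stay within the scatter.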

Compound 3, a percentage reported as activity, at one concentration (the size of the read-out at that concentration, not a potency): 101%
For compound 3 the middle estimate is 4 percentage points below the measured one; the range from low to high includes it.
By their numbers in this assay, from the lowest: compound 1; then compounds 3 and 2 (each within the scatter of the next).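

In this assay, among these compounds, 4-methoxyphenyl in place of 3,4-dichlorophenyl on a carbonyl carbon gives a number 4 percentage points lower from compound 2 to compound 3 (within the scatter), the only step so far that isolates this position. At the concentration tested, the two aryl groups therefore cannot be told apart, although one carries chlorine and the other oxygen. No evidence here bears on this result. Still open, going by these compounds, is whether a 4-aminophenyl or 4-carboxyphenyl group in this place would give a number beyond the scatter, and whether this exchange would read alike on another core.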